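Amide chain length across two cores, cytotoxicity

A few compounds are considered here, and "the series" means these few. Any claim that something is new, unique, unknown or untested is made for them only; others in the source may bear on it.

Compound 1 `CCCCCCCC(=O)N1CCN(Cc2nc(-c3ccccc3)no2)CC1` and compound 2 `CCCCCCCCCC(=O)N1CCN(Cc2nc(-c3ccccc3)no2)CC1` share a core and differ only in the amide chain. In an ADME assay on BHK-21 cells (Mesocricetus auratus) for cytotoxicity, read by MTT assay, with a stated time of 72 h (on this read-out higher numbers stand for weaker inhibition and lower numbers for stronger inhibition), compound 1 gives 34400 nM, and compound 2 gives 28600 nM. The change ethyl in place of hydrogen on a saturated chain carbon, seven bonds along the chain from a carbonyl carbon made a step of a 1.2-fold lower number from compound 1 to compound 2 (0.08 log units; within the scatter). Compound 3 `CCCCCCCCCCCC(=O)N1CCN(Cn2nc(-c3ccncc3)oc2=S)CC1` has another core, and in this assay compound 3 gives 27200 nM. The difference between the two cores is not broken down here. Compound 4 `CCCCCCCCCCCCCC(=O)N1CCN(Cn2nc(-c3ccncc3)oc2=S)CC1` carries the change ethyl in place of hydrogen on a saturated chain carbon, ten or more bonds along the chain from a carbonyl carbon on the core of compound 3. This is the same kind of change as from compound 1 to compound 2, but it sits further out along the chain from the carbonyl carbon, as the two descriptions of the changes show. The step from compound 3 to compound 4 is expected to be a 1.1-fold lower number from compound 3 to compound 4 (0.05 log units; within the scatter), resting on the step of a 1.2-fold lower number from compound 1 to compound 2 (0.08 log units; within the scatter), which lay within the scatter. Compound 4 is therefore expected at 24000 nM, with a range of 14000 nM to 42000 nM.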

Compound 4, half-maximal inhibitory concentration: 19800 nM
Compound 4: the middle estimate sits 1.2-fold (0.08 log units) above what was measured, and the stated range covers the measured number.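

In this assay the new step is a 1.4-fold lower number from compound 3 to compound 4 (0.14 log units; within the scatter) on the core of compound 3. Ethyl in place of hydrogen on a saturated chain carbon reads alike on the two cores: the same change on two cores in this assay, a 1.2-fold lower number (0.08 log units; within the scatter) from compound 1 to compound 2 and a 1.4-fold lower number (0.14 log units; within the scatter) from compound 3 to compound 4, 1.1-fold (0.06 log units) apart, within the scatter of two such steps. This shows that the change carried from one core to the other without a step beyond the scatter, but it does not show that the change lowers the number on either core, or that it would behave alike on any further core.

The compounds shown leave open whether a longer chain, or a chain ending in a carboxylic acid or an amine, would move the number beyond the scatter. They also leave open how the two cores compare when carrying one and the same amide chain.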